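This account rests on a few compounds, and the source may have more. Where it says the series, first, only, none or still open, it means among the compounds named here.

Compound 1 `Cc1ccn2cc(-c3ccc(NC(=O)Nc4cc(C(C)(C)C)on4)cc3)nc2c1`: in a physicochemical assay for solubility (a lower number here means a less soluble compound, a higher number a more soluble compound), compound 1 gives 6830 ug/mL. Compound 2 `C#Cc1ccn2cc(-c3ccc(NC(=O)Nc4cc(C(C)(C)C)on4)cc3)nc2c1`: in this assay compound 2 gives 5840 ug/mL.

Among the measured compounds shown here, on these two numbers compound 2 stands alongside compound 1, the only measured step being a 1.2-fold lower number from compound 1 to compound 2 (0.07 log units; within the scatter), which lies within the scatter. Compound 3 `COc1ccn2cc(-c3ccc(NC(=O)Nc4cc(C(C)(C)C)on4)cc3)nc2c1` differs from compound 2 by methoxy in place of ethynyl on an aromatic carbon. For the measured compounds named here, the single step that bears on this change touches the same position and stayed within the scatter, so no step beyond the scatter is expected here either. Compound 3 is expected to give 6500 ug/mL in this assay, between 3200 ug/mL and 13000 ug/mL, which means an expected step of a 1.1-fold higher number from compound 2 to compound 3 (0.05 log units; within the scatter).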

Compound 3, solubility: 7460 ug/mL
For compound 3 the middle estimate is 1.1-fold (0.06 log units) below the measured one; low and high end bracket the measured number.
By their numbers in this assay, from the lowest: compounds 2, 1 and 3 (each within the scatter of the next).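

On the aromatic carbon opposite the ring nitrogen, an oxygen-bearing group now joins the two carbon-only groups, and in this assay the steps of a 1.3-fold higher number from compound 2 to compound 3 (0.11 log units; within the scatter) and a 1.1-fold higher number from compound 1 to compound 3 (0.04 log units; within the scatter) both stay within the scatter. Methyl, ethynyl and methoxy are therefore not separated at this position by this read-out. Nothing on hand gives a reason for this outcome.

On these data alone, whether an amine, a carboxylic acid or a longer chain here would produce a step beyond the scatter remains open. Equally open, as far as these compounds go, is whether changes elsewhere on the shared core behave in the same way.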